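Chloro for hydrogen on the phenyl ring of compound 3

This account rests on a few compounds, and the source may have more. Where it says the series, first, only, none or still open, it means among the compounds named here.

Measured compounds:
compound 1, `CCOC(=O)c1c(-c2cc3ccccc3oc2=O)nn(-c2ccccc2)c1C(=O)OCC`, 57000 nM
compound 2, `CCOC(=O)c1c(-c2cc3ccccc3oc2=O)nn(-c2cccc(C)c2)c1C(=O)OCC`, 47000 nM
compound 3, `CCOC(=O)c1c(-c2cc3ccc(OC)cc3oc2=O)nn(-c2ccccc2)c1C(=O)OCC`, 33000 nM

All three values come from a functional assay on DU-145 cells (Homo sapiens) for cytotoxicity, read by MTT assay, with a stated time of 48 h; on this read-out higher numbers stand for weaker inhibition and lower numbers for stronger inhibition. Compound 3 sits at the low end of the three numbers, but no one of them stands apart from the others beyond the scatter. The step of a 1.7-fold lower number from compound 1 to compound 3 (0.24 log units; within the scatter) is small. The gap between compound 3 and compound 2 is small as well.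

Compound 4, `CCOC(=O)c1c(-c2cc3ccc(OC)cc3oc2=O)nn(-c2cccc(Cl)c2)c1C(=O)OCC`, differs from compound 3 in one place: chloro in place of hydrogen on an aromatic carbon. Going by the values given here, the one measured step that bears on this change is the step that also alters the same phenyl ring: a 1.2-fold lower number from compound 1 to compound 2 (0.08 log units; within the scatter), a methyl in place of hydrogen at the same kind of site, which did not move the number beyond the scatter. The other step, a 1.7-fold lower number from compound 1 to compound 3 (0.24 log units; within the scatter), concerns the methoxy that compound 3 and compound 4 share, so it adds nothing about the chloro. On this basis no step beyond the scatter is expected in this assay for compound 4; the expected step is a 1.1-fold lower number from compound 3 to compound 4 (0.04 log units; within the scatter). Compound 4 is therefore estimated at 30000 nM, with a range from 12000 nM to 75000 nM.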

Compound 4, half-maximal inhibitory concentration: 38000 nM
The estimate for compound 4 lay 1.3-fold (0.10 log units) below the measured number; measured number inside the range.
By their numbers in this assay, from the lowest: compounds 3, 4, 2 and 1 (each within the scatter of the next).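

In this assay the replacement of hydrogen by chloro on an aromatic carbon, meta to a large group, gives a 1.2-fold higher number from compound 3 to compound 4 (0.06 log units; within the scatter) and so leaves the number within the scatter. The earlier compounds had shown only a methyl on this phenyl ring, in a 1.2-fold lower number from compound 1 to compound 2 (0.08 log units; within the scatter) on the core without the methoxy; the phenyl to 3-chlorophenyl change now gives a second group on this ring, on the core that carries the methoxy, and this step too stays within the scatter. Across these four compounds, neither substituent on this ring separates its compound from its partner beyond the scatter, and none of the pairs shown goes against that, but nothing given here offers a reason for this outcome.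

The compounds shown leave open whether an amine, a carboxylic acid or a longer chain such as butyl on this phenyl ring would produce a step beyond the scatter. They also leave open whether chloro would behave in the same way on the core without the methoxy, since compound 1 has no chloro partner among them.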